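This account rests on a few compounds, and the source may have more. Where it says the series, first, only, none or still open, it means among the compounds named here.

Compound 1 `O=c1ccoc2cc(OCc3cn(Cc4ccccc4)nn3)ccc12` gives > 300000 nM in an ADME assay on L02 cells (Homo sapiens) for cytotoxicity, read by MTT assay, with a stated time of 48 h (a higher number here means a weaker inhibitor, a lower number a stronger inhibitor), which is a limit of the assay.
Compound 2 `O=c1ccoc2cc(OCc3cn(Cc4cccc(F)c4)nn3)ccc12` gives > 300000 nM in this assay, again a limit.
Compound 3 `O=c1ccoc2cc(OCc3cn(Cc4ccc(F)cc4)nn3)ccc12` gives > 300000 nM in this assay, also a limit.

Compound 3 thus stands at the edge of what the assay reports, and it shares that position with both of its neighbours, since (the limit of > 300000 nM in this assay, at which 3 of the 3 values shown sit). The steps that connect the three, a step that the two limits leave unreadable from compound 1 to compound 2, a step that the two limits leave unreadable from compound 1 to compound 3 and a step that the two limits leave unreadable from compound 2 to compound 3, are all left unreadable by the limits at their two ends, so they give no size and no direction.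

Compound 4 `O=c1ccoc2cc(OCc3cn(Cc4ccc([N+](=O)[O-])cc4)nn3)ccc12` differs from compound 3 by nitro in place of fluoro on an aromatic carbon. Among the compounds with values here, no measured step bears on this exchange in a readable way, so nothing from the measured compounds points to a step of any particular size. Compound 3 sits at a limit, and the step of a number no higher from compound 3 to compound 4 (the limit leaves the size open) is expected to be none beyond the scatter. Compound 4 is therefore estimated at 300000 nM in this assay, with a range from 100000 nM to 900000 nM, and most likely the assay will again report only a limit.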

Compound 4, half-maximal inhibitory concentration: > 300000 nM
Compound 4: no number, only a limit (the forecaster's own chance of this, stated with the estimate: 85%); the middle value sits exactly at the limit.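

Compound 4 sits at a limit, as do compound 1, compound 2 and compound 3, so none of the steps joining compound 4 to them can be read in this assay: the limit of > 300000 nM in this assay, at which 4 of the 4 values shown sit.

The compounds shown leave open how far each lies past that limit, and whether hydrogen, fluoro or nitro on the aromatic carbon makes any difference.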